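A few compounds are considered here, and "the series" means these few. Any claim that something is new, unique, unknown or untested is made for them only; others in the source may bear on it.

Compound 1 `COc1ccc(N2C(=O)C(C)(C)c3cccnc32)cc1` and compound 2 `CSc1ccc(N2C(=O)C(C)(C)c3cccnc32)cc1` share one core and differ only in the group on the aromatic carbon of the outer ring. In a functional assay on the whole organism (Pleural cavity) for inhibition, with Rattus norvegicus as the target, at a dose of 25 mg/kg (on this read-out higher numbers stand for more inhibition at the one dose given (going by the name of the read-out) and lower numbers for less inhibition), compound 1 gives 63%, while compound 2 gives 29%; the step of a number 34 percentage points lower from compound 1 to compound 2 (beyond the scatter) is the only measured one, and it places compound 2 as the lower of the two numbers. Compound 3 `C[S+]([O-])c1ccc(N2C(=O)C(C)(C)c3cccnc32)cc1` is the next member: a group of 3 heavy atoms (1 carbon, 1 oxygen, 1 sulfur; no ring) in place of a group of 2 heavy atoms (1 carbon, 1 sulfur; no ring), on an aromatic carbon. For the measured compounds named here, no measured step covers this kind of change, so the one step available, the large drop from compound 1 to compound 2, only shows that the methylsulfanyl compound lies low, not where a group of 3 heavy atoms (1 carbon, 1 oxygen, 1 sulfur; no ring) will lead. Compound 3 is therefore expected to show a number 11 percentage points higher from compound 2 to compound 3 (beyond the scatter), with wide uncertainty. The estimate for compound 3 in this assay is 40%, expected to fall between 15% and 65%.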

Compound 3, a percentage reported as inhibition, in the whole organism at one dose (the size of the read-out at that dose, not a potency): 39%
Compound 3: middle estimate off by 1 percentage points, on the high side, and the stated range covers the measured number.
By their numbers in this assay, from the lowest: compounds 2 and 3 (each within the scatter of the next); then compound 1.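

In this assay, placing an oxygen on the sulfur of the methylsulfanyl group gives a number 10 percentage points higher from compound 2 to compound 3 (within the scatter) and so, on an aromatic carbon para to a large group, the two sulfur groups cannot be told apart. The methoxy group also stays clear of this second sulfur group, with a number 24 percentage points lower from compound 1 to compound 3 (beyond the scatter) as the step, so the gap first seen with the methylsulfanyl group holds for both sulfur groups shown. Nothing available bears on the reason for these numbers.

The compounds shown leave open how a methylsulfonyl group, a fluorine atom or a longer ethoxy chain would compare with methoxy at this place. They also leave open whether the same order would hold at other doses, since each number comes from a single dose.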